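The compounds below may be only part of what the source reports. "The series", "measured", "known", "first", "only" and "open" are said of these compounds alone.

Values in an assay on mitochondria for inhibition of Amine oxidase [flavin-containing] B (Bos taurus), read by fluorescence, with a stated time of 60 min; a higher number here means a weaker inhibitor, a lower number a stronger inhibitor:

compound 1, `COC(=O)CN1C(=O)c2ccccc2NC1c1ccccc1`: 720000 nM
compound 2, `COC(=O)CN1C(=O)c2ccccc2NC1c1ccco1`: 380000 nM
compound 3, `NNC(=O)CCCN1C(=O)c2ccccc2NC1c1ccccc1`: 370000 nM

All three numbers in this assay are high, and the two changes made so far stay within the scatter. From compound 1 to compound 2 the change is furan-2-yl in place of phenyl on a saturated ring carbon, and the step is a 1.9-fold lower number from compound 1 to compound 2 (0.28 log units; within the scatter). From compound 1 to compound 3 the change is 2-(aminocarbamoyl)ethyl in place of methoxycarbonyl on a saturated chain carbon bound to an amide-type nitrogen in a ring, and the step is a 1.9-fold lower number from compound 1 to compound 3 (0.29 log units; within the scatter). Compound 2 and compound 3 give numbers that lie within the scatter of each other, so no order between them can be read.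

Compound 4, `NNC(=O)CCCN1C(=O)c2ccccc2NC1c1ccco1`, has not yet been measured in this assay. It differs from compound 3 by furan-2-yl in place of phenyl on a saturated ring carbon. Going by the values given here, this is the same kind of change as the one from compound 1 to compound 2, but not the same: in compound 1 the saturated ring carbon sits next to the ring atom that bears a (methoxycarbonyl)methyl group (5 heavy atoms), whereas in compound 3 it sits next to the ring atom that bears a 3-(aminocarbamoyl)propyl group (7 heavy atoms). The two cores differ by 2-(aminocarbamoyl)ethyl in place of methoxycarbonyl on a saturated chain carbon bound to an amide-type nitrogen in a ring.

For compound 4 the step from compound 3 is expected to be a 1.7-fold lower number from compound 3 to compound 4 (0.23 log units; within the scatter), resting on the earlier step of a 1.9-fold lower number from compound 1 to compound 2 (0.28 log units; within the scatter), which stayed within the scatter. The estimate for compound 4 in this assay is therefore 220000 nM, with a range from 100000 nM to 480000 nM.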

Compound 4, half-maximal inhibitory concentration: 270000 nM
Compound 4: the middle estimate sits 1.2-fold (0.09 log units) below what was measured; the range from low to high includes it.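

In this assay, furan-2-yl in place of phenyl on the saturated ring carbon gives a 1.4-fold lower number from compound 3 to compound 4 (0.14 log units; within the scatter), and this step reads the same as the one on the core of compound 1: the same change on two cores in this assay, a 1.9-fold lower number (0.28 log units; within the scatter) from compound 1 to compound 2 and a 1.4-fold lower number (0.14 log units; within the scatter) from compound 3 to compound 4, 1.4-fold (0.14 log units) apart, within the scatter of two such steps. The chain change, 2-(aminocarbamoyl)ethyl in place of methoxycarbonyl, gives a 1.4-fold lower number from compound 2 to compound 4 (0.15 log units; within the scatter), and it too carries over between the furan-2-yl and phenyl cores without a readable difference: the same change on two cores in this assay, a 1.9-fold lower number (0.29 log units; within the scatter) from compound 1 to compound 3 and a 1.4-fold lower number (0.15 log units; within the scatter) from compound 2 to compound 4, 1.4-fold (0.14 log units) apart, within the scatter of two such steps. The four compounds therefore fit the two changes acting independently of each other, but every step lies within the scatter, so this agreement does not show that either change moves the number at all, and it is only a weak test of transfer between cores.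

Still open, as far as these compounds go, is whether any replacement on the saturated ring carbon, such as thiophen-2-yl or a chlorophenyl group, or any other chain end, such as a carboxylic acid or an amine in place of the aminocarbamoyl group, gives a step beyond the scatter. Only a step of that size would test whether a change keeps its size from one core to the other in this series.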